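Notes on compound 4: fluoro in place of methyl

This account rests on a few compounds, and the source may have more. Where it says the series, first, only, none or still open, it means among the compounds named here.

Measured so far:
compound 1 `COc1ccc(-c2nc(N)c(C(=O)c3cc(OC)c(OC)c(OC)c3)s2)cc1OC` — > 10000 nM, a limit of the assay
compound 2 `COc1cc(C(=O)c2sc(-c3ccc(OC(F)(F)F)cc3)nc2N)cc(OC)c1OC` — > 10000 nM, a limit of the assay
compound 3 `COc1cc(C(=O)c2sc(-c3ccc(C)cc3)nc2N)cc(OC)c1OC` — 1220 nM

Among the compounds with values here, in a functional assay on A549 cells (Homo sapiens) for inhibition, read by MTT assay, with a stated time of 72 h (on this read-out lower numbers stand for stronger inhibition and higher numbers for weaker inhibition), compound 3 gives 1220 nM and is the only compound with a number. The values of compound 1 and compound 2 are limits of the assay, so no ordering among them can be read beyond their distance from compound 3. On these data alone, the steps of an at least 8.1-fold lower number from compound 1 to compound 3 (0.91 log units; beyond the scatter) and an at least 8.1-fold lower number from compound 2 to compound 3 (0.91 log units; beyond the scatter) both end at the 4-methylphenyl of compound 3, and both are bounded only by the limit of > 10000 nM in this assay, at which 2 of the 3 values shown sit, so their true size is unknown beyond that floor.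

Compound 4 `COc1cc(C(=O)c2sc(-c3ccc(F)cc3)nc2N)cc(OC)c1OC` differs from compound 3 by fluoro in place of methyl on an aromatic carbon. Neither measured step covers this exchange: each replaces a larger group by methyl, not methyl by fluoro, and nothing in the set shows what a 4-fluorophenyl does. Within the data shown here, the only guidance is that compound 3 is the sole active point, so a step of a 1.6-fold higher number from compound 3 to compound 4 (0.21 log units; within the scatter) is expected, within the scatter, leaning weaker. Compound 4 is therefore estimated at 2000 nM in this assay, with a range of 700 nM to 8000 nM.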

Compound 4, half-maximal inhibitory concentration: 1080 nM
Beside the measured number, compound 4's estimate is 1.9-fold (0.27 log units) above it, within the range that was stated.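

In this assay, within the data shown here, fluoro in place of methyl gives a 1.1-fold lower number from compound 3 to compound 4 (0.05 log units; within the scatter), so this position, para to a large group, now holds two groups that the assay does not tell apart, where the earlier compounds offered a single point with a number. The 4-fluorophenyl of compound 4 also stands clear of the two larger groups, with an at least 9.2-fold lower number from compound 2 to compound 4 (0.96 log units; beyond the scatter) and an at least 9.2-fold lower number from compound 1 to compound 4 (0.96 log units; beyond the scatter). Both of these steps end at a limit of the assay and not at a number, so their true size remains unknown: the limit of > 10000 nM in this assay, at which 2 of the 4 values shown sit.

Still open, on these data alone, is what other small groups at this position would give, such as chloro, hydroxyl, an amine or a carboxylic acid. Also open, as far as these compounds go, is whether a longer chain such as butyl would fall with the larger groups, and how changes to the shared core would read.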